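A few compounds are considered here, and "the series" means these few. Any claim that something is new, unique, unknown or untested is made for them only; others in the source may bear on it.

Measured so far in a functional assay (brain) for inhibition, with Rattus norvegicus as the target; a higher number here means a weaker inhibitor, a lower number a stronger inhibitor:
compound 1 `Cc1c(C)c2c(c(C)c1O)CCC(C)(C(=O)N1CCN(c3ncccn3)CC1)O2` gives 23000 nM
compound 2 `COc1ccc(N2CCN(C(=O)C3(C)CCc4c(C)c(O)c(C)c(C)c4O3)CC2)cc1` gives 700 nM
compound 3 `Cc1c(C)c2c(c(C)c1O)CCC(C)(C(=O)N1CCNCC1)O2` gives 10000 nM

Compound 3 stands second highest of the three numbers; its nearest neighbour is compound 1, at a 2.3-fold lower number from compound 1 to compound 3 (0.36 log units; beyond the scatter), and its furthest is compound 2, at a 14-fold higher number from compound 2 to compound 3 (1.15 log units; beyond the scatter). Compound 4 `Cc1c(C)c2c(c(C)c1O)CCC(C)(C(=O)Nc1ccccn1)O2` differs from compound 3 by (pyridin-2-yl)amino in place of piperazin-1-yl on a carbonyl carbon. The steps measured so far all alter what sits on the amine nitrogen in the ring: a 33-fold lower number from compound 1 to compound 2 (1.52 log units; beyond the scatter), a 2.3-fold lower number from compound 1 to compound 3 (0.36 log units; beyond the scatter) and a 14-fold higher number from compound 2 to compound 3 (1.15 log units; beyond the scatter). None of them removes that ring, so their bearing on the present change is indirect. They do show that an aromatic group in this region can move this assay strongly in either direction, with pyrimidin-2-yl giving the highest number and 4-methoxyphenyl the lowest. The expectation for compound 4 is therefore a step of uncertain direction and modest size, a 1.7-fold lower number from compound 3 to compound 4 (0.22 log units; within the scatter). Compound 4 is estimated at 6000 nM, with a range from 1500 nM to 25000 nM.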

Compound 4, half-maximal inhibitory concentration: 1800 nM
Compound 4: middle estimate off by 3.3-fold (0.52 log units), on the high side; low and high end bracket the measured number.
By their numbers in this assay, from the lowest: compound 2; then compound 4; then compound 3; then compound 1.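

In this assay, a 5.6-fold lower number from compound 3 to compound 4 (0.74 log units; beyond the scatter), so the piperazin-1-yl group on the carbonyl carbon can be given up without loss of inhibition, at least on this core. The earlier steps shown here changed only the group on the amine nitrogen of a retained ring, whereas this one shows that the ring itself can be replaced, here by (pyridin-2-yl)amino, which brings a six-membered aromatic ring. No supporting measurement is available to explain this step.

The compounds shown do not separate the contribution of the aromatic ring from that of its ring nitrogen, and phenylamino on the same carbonyl carbon would address that comparison. As far as these compounds go, whether the aromatic ring must sit directly on the amide nitrogen also remains open, a question that benzylamino would test.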